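Shifting the Chlorine on a Urea Lipoxygenase Inhibitor

The source may hold more compounds than are shown below. What is called first, only, known or untested is meant among the compounds shown, and "the series" means these compounds.

Compound 1 `Cc1cc(NC(=O)Nc2cccc(Cl)c2)ccc1OCc1nc2ccccc2s1`: 2090 nM
Compound 2 `O=C(Nc1ccc(OCc2nc3ccccc3s2)cc1)Nc1ccccc1Cl`: 360 nM

In an assay on isolated protein for inhibition of Polyunsaturated fatty acid 5-lipoxygenase (Homo sapiens), read by HPLC, with a stated time of 10 min (a higher number here means a weaker inhibitor, a lower number a stronger inhibitor), compound 2 gives 360 nM, the lower of the two numbers; compound 1 gives 2090 nM, and that gap lies beyond the usual scatter. Compound 3 `O=C(Nc1ccc(OCc2nc3ccccc3s2)cc1)Nc1cccc(Cl)c1` differs from compound 2 in one place only: 3-chlorophenyl in place of 2-chlorophenyl on an amide-type nitrogen. Among the measured compounds shown here, no measured pair shows this change on its own, so its size is uncertain; a modest weakening is expected, a 2.5-fold higher number from compound 2 to compound 3 (0.40 log units; beyond the scatter), since the only other compound with this arrangement sits higher. Compound 3 is therefore estimated at 900 nM, with a range from 300 nM to 2700 nM.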

Compound 3, half-maximal inhibitory concentration: 170 nM
For compound 3 the middle estimate is 5.3-fold (0.72 log units) above the measured one; the measured number lies below the stated range.
By their numbers in this assay, from the lowest: compound 3; then compound 2; then compound 1.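

Moving the chlorine turns out to help: 3-chlorophenyl in place of 2-chlorophenyl on the amide-type nitrogen gives a modest gain (a 2.1-fold lower number from compound 2 to compound 3 (0.33 log units; beyond the scatter)). Compound 3 also reveals a second single change, since hydrogen in place of methyl on an aromatic carbon gives a large gain (a 12-fold lower number from compound 1 to compound 3 (1.09 log units; beyond the scatter)). Nothing measured here explains either step.

Going by these compounds, whether a fluorine or a methoxy group would behave like the chlorine at these places remains open. So does the effect of an ethyl group in place of the methyl.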